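This account rests on a few compounds, and the source may have more. Where it says the series, first, only, none or still open, it means among the compounds named here.

Measured in a functional assay on MGC-803 cells (Homo sapiens) for inhibition, read by sulforhodamine B assay; on this read-out higher numbers stand for weaker inhibition and lower numbers for stronger inhibition:
Compound 1, `CCCc1ccc(NC2=CC(=O)c3nc4n(c3C2=O)[C@H]2OC[C@@H](O)[C@H]2OC4)cc1`, gives 1560 nM.
Compound 2, `O=C1C(Nc2ccc(Br)cc2)=CC(=O)c2c1nc1n2[C@H]2OC[C@@H](O)[C@H]2OC1`, gives 2020 nM.
Compound 3, `COc1cccc(NC2=CC(=O)c3nc4n(c3C2=O)[C@H]2OC[C@@H](O)[C@H]2OC4)c1`, gives 1780 nM.

Compound 2 carries the highest of the three numbers, but its gaps to compound 3 and compound 1 lie within the scatter, so no order among the three can be read. The next compound, compound 4, `O=C1C(Nc2cccc(Cl)c2)=CC(=O)c2c1nc1n2[C@H]2OC[C@@H](O)[C@H]2OC1`, differs from compound 2 by 3-chlorophenyl in place of 4-bromophenyl on an amine nitrogen. For the measured compounds named here, the one comparable step on this series, an exchange of the aryl group on the amine nitrogen, is a 1.1-fold higher number from compound 1 to compound 3 (0.06 log units; within the scatter), a change within the scatter, and compounds 1 to 3 together span only a narrow window. No step beyond the scatter is therefore expected in this assay; the step from compound 2 to compound 4 is estimated at a 1.1-fold lower number from compound 2 to compound 4 (0.03 log units; within the scatter). Compound 4 is expected to give 1900 nM, between 900 nM and 4000 nM.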

Compound 4, half-maximal inhibitory concentration: 1530 nM
Compound 4: middle estimate off by 1.2-fold (0.09 log units), on the high side; the range from low to high includes it.
By their numbers in this assay, from the lowest: compounds 4, 1, 3 and 2 (each within the scatter of the next).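

In this assay, the exchange of 3-chlorophenyl for 4-bromophenyl on the amine nitrogen gives a 1.3-fold lower number from compound 2 to compound 4 (0.12 log units; within the scatter), so a second aryl exchange, this time between two halogen-bearing rings, also fails to move the number beyond the scatter. Halogen identity and ring position changed together here, and even this double difference leaves the read-out unshifted. No measurement bearing on the reason is available.

The separate contributions of the halogen and its ring position remain unresolved. Going by these compounds, it also remains open whether a carboxylic acid or a dimethylamino group on the phenyl ring would shift the number beyond the scatter.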